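A few compounds are considered here, and "the series" means these few. Any claim that something is new, unique, unknown or untested is made for them only; others in the source may bear on it.

Going by the values given here, compound 1, with structure `COc1ccc(C2CC(=NO)CC(c3ccc(OC)cc3)N2C)cc1`, is the weaker of the two compounds measured so far: in a functional assay, with a stated time of 30 min (a higher number here means a weaker inhibitor, a lower number a stronger inhibitor), compound 1 gives 380000 nM, the highest of the two numbers. Among the compounds with values here, its only measured neighbour is compound 2, with structure `COc1ccc(C2CC(=NOC(=O)c3ccc(Cl)cc3)CC(c3ccc(OC)cc3)N2C)cc1`, which in this assay gives 135000 nM. Within the data shown here, the one measured step, a 2.8-fold lower number from compound 1 to compound 2 (0.45 log units; beyond the scatter), comes from placing a (4-chlorophenyl)carbonyl in place of hydrogen on an oxygen, and it lowers the number modestly.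

Compound 3, with structure `COc1ccc(C2CC(=NOC(=O)c3ccc(OC)cc3OC)CC(c3ccc(OC)cc3)N2C)cc1`, is built from compound 1 by the change ((2,4-dimethoxyphenyl)carbonyl in place of hydrogen on an oxygen). Among the measured compounds shown here, the change is of the same kind as the one measured step: again a ring-bearing carbonyl group enters on the same oxygen, replacing a hydrogen. For the measured compounds named here, that step, a 2.8-fold lower number from compound 1 to compound 2 (0.45 log units; beyond the scatter), is the only guide available, and it was modest but beyond the scatter. A similar modest step toward a lower number is therefore expected in this assay, as a 2.5-fold lower number from compound 1 to compound 3 (0.40 log units; beyond the scatter). Going by the values given here, for compound 3 the expected value is estimated at 150000 nM, with a likely range from 60000 nM to 350000 nM, since only one step of this kind has been seen.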

Compound 3, half-maximal inhibitory concentration: 80000 nM
The estimate for compound 3 lay 1.9-fold (0.27 log units) above the measured number; measured number inside the range.
By their numbers in this assay, from the lowest: compounds 3 and 2 (each within the scatter of the next); then compound 1.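

In this assay, a second ring-bearing carbonyl group on the oxygen whose other neighbour is the double-bonded nitrogen gives a 4.8-fold lower number from compound 1 to compound 3 (0.68 log units; beyond the scatter), so the lowering seen with compound 2 is not limited to the 4-chlorophenyl version: both carbonyl groups shown lower the number, and neither goes against this. Exchanging the ring on the carbonyl carbon, 2,4-dimethoxyphenyl in place of 4-chlorophenyl, gives a 1.7-fold lower number from compound 2 to compound 3 (0.23 log units; within the scatter), which lies within the scatter, so this assay does not separate these two rings even though one carries a chlorine and the other two methoxy groups. No supporting measurement is available to explain the lowering on the oxygen or the lack of separation between the two rings.

Both carbonyl groups shown carry an aromatic ring, so it remains open whether that ring is needed at all, or whether a plain acetyl group or a longer alkyl chain on the same carbonyl would lower the number as well. Going by these compounds, it also remains open whether an amine or a carboxylic acid on the ring would move the number beyond the scatter, where the chlorine and methoxy groups did not.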